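Swapping the Sulfur Group of Compound 2

The source may report more compounds than this note shows. Statements on the series, on what has been measured and on what is new or still open speak of the compounds shown alone.

Measured in a functional assay (Homo sapiens) for inhibition; on this read-out higher numbers stand for weaker inhibition and lower numbers for stronger inhibition:
- compound 1 `CSc1ccc(CSc2nc(-c3ccc(F)cc3)c(-c3ccncc3)[nH]2)cc1` gives 670 nM
- compound 2 `CS(=O)(=O)c1ccc(CSc2nc(-c3ccc(F)cc3)c(-c3ccncc3)[nH]2)cc1` gives 330 nM
- compound 3 `C[S+]([O-])c1ccc(CSc2nc(-c3ccc(F)cc3)c(-c3cccnc3)[nH]2)cc1` gives 98000 nM

Compound 2 has the lowest number of the three, which makes it the strongest inhibitor here. Compound 4 `CSc1cccc(CSc2nc(-c3ccc(F)cc3)c(-c3ccncc3)[nH]2)c1` differs from it by 3-(methylsulfanyl)phenyl in place of 4-(methylsulfonyl)phenyl on a saturated chain carbon bound to a sulfur. Among the measured compounds shown here, one measured step bears on this swap, the modest 2.0-fold lower number from compound 1 to compound 2 (0.31 log units; beyond the scatter), which exchanged methylsulfanyl for methylsulfonyl. Compound 4 returns to methylsulfanyl, so that step suggests a modest rise in this assay. Nothing measured here tests 3-(methylsulfanyl)phenyl itself, so the range stays wide. The expected step is a 2.4-fold higher number from compound 2 to compound 4 (0.38 log units; beyond the scatter). For compound 4 the estimate is 800 nM, with an expected range from 250 nM to 2500 nM.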

Compound 4, half-maximal inhibitory concentration: 550 nM
Estimate against measurement, compound 4: 1.5-fold (0.16 log units) above; measured number inside the range.
By their numbers in this assay, from the lowest: compounds 2, 4 and 1 (each within the scatter of the next, the first and the last beyond it); then compound 3.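

In this assay, 3-(methylsulfanyl)phenyl in place of 4-(methylsulfanyl)phenyl gives a 1.2-fold lower number from compound 1 to compound 4 (0.09 log units; within the scatter) and 3-(methylsulfanyl)phenyl in place of 4-(methylsulfonyl)phenyl gives a 1.7-fold higher number from compound 2 to compound 4 (0.22 log units; within the scatter), both within the usual scatter. Among these three compounds, then, neither change separates compound 4 from its partner on this read-out, although compound 1 and compound 2 do stand apart from each other. No supporting data explain this result.

The compounds shown leave open how 3-(methylsulfonyl)phenyl would read at this position. They also leave open what an amine or a carboxylic acid on this ring would do.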